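A few compounds are considered here, and "the series" means these few. Any claim that something is new, unique, unknown or untested is made for them only; others in the source may bear on it.

Measured compounds in a functional assay on A549 cells (Homo sapiens) for inhibition, read by MTT assay, with a stated time of 72 h; a lower number here means a stronger inhibitor, a higher number a weaker inhibitor:
- compound 1 `C=C(c1ccc(Cl)c(Cl)c1)C1COC2(CCCCC2)OO1`: 12800 nM
- compound 2 `C=C(c1ccc(Cl)c(Cl)c1Cl)C1COC2(CCCCC2)OO1`: 1370 nM
- compound 3 `C=C(c1ccc(F)cc1F)C1COC(C)(C)OO1`: > 100000 nM (a limit of the assay, not a number)

Of the two true numbers in this assay, compound 2 has the lower, 1370 nM, and compound 1 stands nearest to it at 12800 nM in the same read-out. Compound 3 gives only a limit, > 100000 nM, and cannot be ranked more closely.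

Not yet measured is compound 4 `C=C(c1ccc(Cl)cc1Cl)C1COC2(CCCCC2)OO1`, which departs from compound 2 by a single change: hydrogen in place of chloro on an aromatic carbon. Among the measured compounds shown here, only one measured step bears on this, the reverse kind of change, chloro in place of hydrogen on an aromatic carbon, a 9.3-fold lower number from compound 1 to compound 2 (0.97 log units; beyond the scatter), which is modest but beyond the scatter. That step concerned a different ring carbon, and compound 4 keeps the chloro gained there, so it guides the direction better than the size. With that single step as a guide, losing a chloro is expected to raise the number by a similar or somewhat smaller amount. The expected change is a 3.6-fold higher number from compound 2 to compound 4 (0.56 log units; beyond the scatter) in this assay. For compound 4 the estimated value is 5000 nM, with an expected range from 1500 nM to 18000 nM in this read-out.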

Compound 4, half-maximal inhibitory concentration: 810 nM
Compound 4: the middle estimate sits 6.2-fold (0.79 log units) above what was measured; the whole stated range lies above it.
By their numbers in this assay, from the lowest: compounds 4 and 2 (each within the scatter of the next); then compound 1. At a limit, above all of these: compound 3.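

In this assay, the chloro that sits ortho to two chloro groups and meta to a large group can give way to hydrogen without a difference that stands out from the usual scatter (a 1.7-fold lower number from compound 2 to compound 4 (0.23 log units; within the scatter)). Among the compounds shown here, the one earlier step, on a different aromatic carbon of the same ring, lay beyond the scatter (a 9.3-fold lower number from compound 1 to compound 2 (0.97 log units; beyond the scatter)), so across these two steps a chloro does not count alike at each carbon it occupies, and the earlier step cannot be carried over to this position. Nothing measured for these compounds accounts for that contrast between the two carbons.

For the compounds shown here, what remains open is how this carbon responds to a group other than chloro or hydrogen, such as a methoxy group, a methyl group or a nitrile, since the only comparison at this position is between those two. Going by these compounds, it is also open whether the same indifference holds when an amine or a carboxylic acid stands elsewhere on the ring, as both steps rest on chloro substituents alone.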